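The source may hold more compounds than are shown below. What is called first, only, known or untested is meant among the compounds shown, and "the series" means these compounds.

Three compounds have been measured in a toxicity assay on Vero C1008 cells (Chlorocebus sabaeus) for cytotoxicity, read by neutral red uptake, with a stated time of 5 days; a higher number here means that more compound is tolerated, a lower number that less compound is tolerated:

Compound 1 `C[C@H](NC(=O)C(c1cccnc1)N(C(=O)c1ccco1)c1ccc([Si](C)(C)C)cc1)c1ccccc1` gives 19400 nM.
Compound 2 `C[C@H](NC(=O)C(c1cccnc1)N(C(=O)c1ccco1)c1ccc(-c2ccccc2)cc1)c1ccccc1` gives > 200000 nM, which is a limit of the assay and not a number.
Compound 3 `C[C@H](NC(=O)C(c1cccnc1)N(C(=O)c1ccno1)c1ccc(-c2ccccc2)cc1)c1ccccc1` gives > 200000 nM, likewise a limit and not a number.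

Compound 2 therefore stands at the limit, as the limit of > 200000 nM in this assay, at which 2 of the 3 values shown sit, shows, and has no number of its own. The step of an at least 10-fold higher number from compound 1 to compound 2 (1.01 log units; beyond the scatter) rose up to that limit, while the step that the two limits leave unreadable from compound 2 to compound 3 runs between two limits and cannot be read.

Compound 4 `O=C(NCCCc1ccccc1)C(c1cccnc1)N(C(=O)c1ccco1)c1ccc(-c2ccccc2)cc1` differs from compound 2 in one place: 3-phenylpropyl in place of 1-phenylethyl on an amide-type nitrogen. Among the measured compounds shown here, neither measured step touches this part of the shared core: the one readable step, an at least 10-fold higher number from compound 1 to compound 2 (1.01 log units; beyond the scatter), concerned a group on an aromatic carbon and ended at the limit, and the other concerned a group on a carbonyl carbon. For the measured compounds named here, no measured step therefore bears directly on the change in compound 4. For compound 4 the expected step in this assay is a number no higher from compound 2 to compound 4 (the limit leaves the size open), with a real chance that only the limit is reported again. The estimate for compound 4 is 200000 nM, between 50000 nM and 400000 nM.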

Compound 4, half-maximal cytotoxic concentration: > 200000 nM
Compound 4: no number, only a limit; the forecaster's own chance of this, stated with the estimate: 70%; the middle value sits exactly at the limit.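

In this assay compound 4 gives > 200000 nM, which is a limit of the assay and not a number. Among the compounds shown here, compound 2 also stands at a limit, and no step between compound 2 and compound 4 can be read. As far as these compounds go, whether 3-phenylpropyl in place of 1-phenylethyl changes the tolerated concentration at all stays open.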